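This account rests on a few compounds, and the source may have more. Where it says the series, first, only, none or still open, it means among the compounds named here.

Working notes on the series.

Three compounds share the core seen in compound 1 `Cn1c(CN2CCN(c3nc(Cl)ccc3C(F)(F)F)CC2)nc2cc(C#N)ccc21` and have been measured in an assay on CHO cells with metabotropic glutamate receptor 2 (Homo sapiens) as the target, read by FLIPR; a higher number here means that more compound is needed for the effect, a lower number that less compound is needed. Compound 1 gives 50.1 nM, the lowest number of the three. Compound 2 `Cn1c(CN2CCN(c3ccccc3C(F)(F)F)CC2)nc2ccccc21` gives 316 nM in this assay, and compound 3 `Cn1c(CN2CCN(c3ccccc3F)CC2)nc2ccccc21` gives 794 nM. Within the data shown here, the only single-point step among the measured compounds is a 2.5-fold higher number from compound 2 to compound 3 (0.40 log units; beyond the scatter), which sits on the aryl ring attached to the piperazine, not on the core.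

Compound 4 `COc1ccc2c(c1)nc(CN1CCN(c3nc(Cl)ccc3C(F)(F)F)CC1)n2C` differs from compound 1 in one place: methoxy in place of cyano on an aromatic carbon. The group sits on an aromatic carbon of the six-membered aromatic ring of carbon only, part of the fused system of two rings, meta to a fused ring and para to a fused ring. No measured step touches this position, so the direction of the change in this assay is not anchored by any pair shown. Among the measured compounds shown here, the measured step from compound 2 to compound 3 shows only that a single-group swap moves the number by a modest amount. On that basis a modest shift toward a higher number, or none beyond the scatter, is expected for compound 4, with a 1.8-fold higher number from compound 1 to compound 4 (0.25 log units; within the scatter) as the estimated step.

The estimate for compound 4 in this assay is therefore 90 nM, with a range from 30 nM to 280 nM.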

Compound 4, half-maximal effective concentration: 251 nM
Compound 4: the middle estimate sits 2.8-fold (0.45 log units) below what was measured; low and high end bracket the measured number.
By their numbers in this assay, from the lowest: compound 1; then compounds 4 and 2 (each within the scatter of the next); then compound 3.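

Among these compounds, this is the first measured change on the six-membered aromatic ring of carbon only, part of the fused system of two rings, and in this assay methoxy in place of cyano gives a 5.0-fold higher number from compound 1 to compound 4 (0.70 log units; beyond the scatter), with the rest of compound 1 held fixed. The position is therefore not silent in this assay: the two groups match in heavy-atom count, in hydrogen-bond acceptors and donors and in net charge, yet the step lies beyond the scatter, so those counts alone do not set the number here. No measurement in hand bears on what lies behind this step.

From the compounds shown here alone, only cyano and methoxy can be compared at this position, so it remains open how other groups there, such as an amine, a carboxylic acid or a longer alkoxy chain, would move the number. Also open, going by these compounds, is whether the same swap gives a step of similar size and direction when the aryl group on the piperazine is that of compound 2 or compound 3 instead of that of compound 1.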